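Para substituent series on the propanediamine sulfonamide scaffold

A few compounds are considered here, and "the series" means these few. Any claim that something is new, unique, unknown or untested is made for them only; others in the source may bear on it.

Measured compounds in a functional assay on PANC-1 cells (Homo sapiens) for inhibition, read by MTT assay, with a stated time of 72 h; a lower number here means a stronger inhibitor of growth, a higher number a weaker inhibitor of growth:
- compound 1, `O=S(=O)(NCCCNCc1ccc(C(F)(F)F)cc1)c1cc(C(F)(F)F)cc(C(F)(F)F)c1`: 3200 nM
- compound 2, `O=S(=O)(NCCCNCc1ccccc1)c1cc(C(F)(F)F)cc(C(F)(F)F)c1`: 16000 nM
- compound 3, `O=S(=O)(NCCCNCc1ccc(Br)cc1)c1cc(C(F)(F)F)cc(C(F)(F)F)c1`: 2200 nM

Compound 3 gives the lowest number of the three. Its distance from compound 1 is a 1.5-fold lower number from compound 1 to compound 3 (0.16 log units; within the scatter), which leaves the two indistinguishable; its distance from compound 2 is a 7.3-fold lower number from compound 2 to compound 3 (0.86 log units; beyond the scatter), a clear separation. Compound 2, with hydrogen at this position, stands apart from both, as the step of a 5.0-fold higher number from compound 1 to compound 2 (0.70 log units; beyond the scatter) also shows.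

Compound 4, `O=S(=O)(NCCCNCc1ccc(-c2ccccc2)cc1)c1cc(C(F)(F)F)cc(C(F)(F)F)c1`, has not yet been measured in this assay. The change from compound 3 is phenyl in place of bromo on an aromatic carbon. Within the data shown here, two measured steps bear on it: a 7.3-fold lower number from compound 2 to compound 3 (0.86 log units; beyond the scatter) and a 1.5-fold lower number from compound 1 to compound 3 (0.16 log units; within the scatter). Together they show that bromo and trifluoromethyl at this position give similar numbers and that hydrogen gives a higher one; no measured compound carries a ring at this position, so the size of phenyl is not covered by any step. The expectation is therefore that compound 4 lands near compound 3, with a step of a 1.2-fold lower number from compound 3 to compound 4 (0.09 log units; within the scatter) that may fall within the scatter, and with wider uncertainty than the measured steps. The estimate for compound 4 in this assay is 1800 nM, within 600 nM to 6000 nM.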

Compound 4, concentration for 50% growth inhibition: 2500 nM
For compound 4 the middle estimate is 1.4-fold (0.14 log units) below the measured one; measured number inside the range.
By their numbers in this assay, from the lowest: compounds 3, 4 and 1 (each within the scatter of the next); then compound 2.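

In this assay, this position accepts a ring: phenyl, with 6 heavy atoms, cannot be told apart from bromo, with 1 heavy atom (a 1.1-fold higher number from compound 3 to compound 4 (0.06 log units; within the scatter)), or from trifluoromethyl (a 1.3-fold lower number from compound 1 to compound 4 (0.11 log units; within the scatter)). The separation from the unsubstituted compound holds with the ring in place (a 6.4-fold lower number from compound 2 to compound 4 (0.81 log units; beyond the scatter)), so compound 1, compound 3 and compound 4 now form one cluster, with compound 2 apart from it; among these three, a reading of group size gives no trend, as the heavy-atom count changes while the numbers stay within the scatter. No measurement on these compounds speaks to what lies behind this.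

Still open, on these data alone, is whether the cluster extends to an amine, a carboxylic acid or a longer chain at this position, or to phenyl bearing a further group on the added ring. Also open is how far the picture depends on the trifluoromethyl groups elsewhere on the shared core and on the propanediamine chain, since all the compounds shown keep both unchanged.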